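The compounds below may be only part of what the source reports. "The series", "measured", "known", "first", "only" and "open" are said of these compounds alone.

Measured in a functional assay on HCT-116 cells (Homo sapiens) for inhibition, read by MTT assay, with a stated time of 48 h; a higher number here means a weaker inhibitor, a lower number a stronger inhibitor:
Compound 1 `COc1cc(-c2cc(-c3ccc(Br)cc3)nc(-c3ccccc3)n2)cc(OC)c1OC`: 4320 nM
Compound 2 `COc1ccc(-c2cc(-c3cc(OC)c(OC)c(OC)c3)nc(-c3ccccc3)n2)c(OC)c1`: > 25000 nM
Compound 3 `COc1cc(-c2cc(-c3cccc(O)c3)nc(-c3ccccc3)n2)cc(OC)c1OC`: 20400 nM

Compound 3, at 20400 nM, holds the higher of the two actual numbers, and the other number lies beyond the scatter from it: a 4.7-fold higher number from compound 1 to compound 3 (0.67 log units; beyond the scatter). Compound 2 reports only a limit, > 25000 nM. The floor of its step lies within the scatter, an at least 1.2-fold lower number from compound 2 to compound 3 (0.08 log units; that floor lies within the scatter), so those two cannot be ordered.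

Compound 4 `COc1ccc(-c2cc(-c3cc(OC)c(OC)c(OC)c3)nc(-c3ccccc3)n2)cc1` carries 4-methoxyphenyl in place of 3-hydroxyphenyl on an aromatic carbon. Within the data shown here, two measured steps bear on this change. Exchanging 4-bromophenyl for 3-hydroxyphenyl gave a 4.7-fold higher number from compound 1 to compound 3 (0.67 log units; beyond the scatter), while exchanging it for 2,4-dimethoxyphenyl gave an at least 5.7-fold higher number from compound 1 to compound 2 (0.76 log units; beyond the scatter). The entering group resembles the 4-bromophenyl of compound 1, at 4320 nM, in its name, but it also shares a methoxy group with the 2,4-dimethoxyphenyl of compound 2. A modest move towards a lower number is therefore expected in this assay, smaller than the full gap between the two measured numbers. The estimated step is a 2.3-fold lower number from compound 3 to compound 4 (0.36 log units; beyond the scatter). For compound 4 the estimated value is 9000 nM, with an expected range from 3500 nM to 25000 nM.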

Compound 4, half-maximal inhibitory concentration: 4780 nM
The estimate for compound 4 lay 1.9-fold (0.27 log units) above the measured number, and the stated range covers the measured number.
By their numbers in this assay, from the lowest: compounds 1 and 4 (each within the scatter of the next); then compound 3. At a limit, above all of these: compound 2.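

In this assay, 4-methoxyphenyl in place of 3-hydroxyphenyl gave a 4.3-fold lower number from compound 3 to compound 4 (0.63 log units; beyond the scatter), while methoxy in place of bromo gave a 1.1-fold higher number from compound 1 to compound 4 (0.04 log units; within the scatter), so the methoxy and bromo groups on this phenyl ring cannot be told apart here. Hydrogen in place of methoxy gave an at least 5.2-fold lower number from compound 2 to compound 4 (0.71 log units; beyond the scatter), which shows that a methoxy group on this ring is not in itself what separates 2,4-dimethoxyphenyl from the better-reading groups. Compound 2 stands at a limit, so that step is only a floor: the limit of > 25000 nM in this assay, at which 1 of the 4 values shown sits.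

The 3-hydroxyphenyl and 4-methoxyphenyl groups differ both in the substituent and in where it sits, so the compounds shown do not separate those two changes. As far as these compounds go, how an amine or a carboxylic acid in place of the methoxy would read also remains open.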